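Shortening the ether chain: expectation for compound 3

A few compounds are considered here, and "the series" means these few. Any claim that something is new, unique, unknown or untested is made for them only; others in the source may bear on it.

compound 1 `COC1(c2ccc(Br)cc2)SC=C(C)n2c1noc2=O` — > 100000 nM
compound 2 `CC/C=C/COC1(c2ccc(Cl)cc2)SC=C(C)n2c1noc2=O` — 88000 nM

Among the compounds with values here, in a functional assay on A2780/DX3 cells (Homo sapiens) for antiproliferative activity, read by MTT assay, with a stated time of 3 days (a lower number here means a stronger inhibitor, a higher number a weaker inhibitor), compound 2 gives 88000 nM, the only plain number recorded there. Compound 1 reaches only a limit, > 100000 nM. That figure is the limit of > 100000 nM in this assay, at which 1 of the 2 values shown sits. Compound 3 `COC1(c2ccc(Cl)cc2)SC=C(C)n2c1noc2=O` differs from compound 2 by hydrogen in place of but-1-en-1-yl on a saturated chain carbon bound to an oxygen on a saturated carbon. Within the data shown here, no measured pair covers this step. The step is expected to weaken inhibition modestly, by a 1.7-fold higher number from compound 2 to compound 3 (0.23 log units; within the scatter), or to stay within the scatter. Compound 3 is estimated at 150000 nM in this assay, between 60000 nM and 400000 nM, and may well be returned as a limit.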

Compound 3, half-maximal inhibitory concentration: 113000 nM
Compound 3: middle estimate off by 1.3-fold (0.12 log units), on the high side, within the range that was stated.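

In this assay, within the data shown here, the change from (pent-2-en-1-yl)oxy to methoxy gives the first readable step at this position: a 1.3-fold higher number from compound 2 to compound 3 (0.11 log units; within the scatter). Removing the but-1-en-1-yl part of the chain therefore leaves the number within the scatter. The step of chloro in place of bromo cannot be read, because compound 1 is only a limit: the limit of > 100000 nM in this assay, at which 1 of the 3 values shown sits.

From the compounds shown here alone, whether an amine or a carboxylic acid on this chain would move the number beyond the scatter remains open. The same holds for a chain longer than pent-2-en-1-yl.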